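Swapping a carboxy for a phenyl on a thiourea ether

A few compounds are considered here, and "the series" means these few. Any claim that something is new, unique, unknown or untested is made for them only; others in the source may bear on it.

Compound 1 `NC(=S)Nc1cccc(OCCCCCOc2ccc(Cl)cc2)c1` and compound 2 `NC(=S)Nc1cccc(OCCCCCOc2ccc(C(=O)O)cc2)c1` share one core. In an ADME assay on Ava5 cells (Homo sapiens) for cytotoxicity (on this read-out higher numbers stand for lower toxicity in this test and lower numbers for higher toxicity in this test), compound 1 gives 7000 nM. Compound 2 reaches only a limit of the assay, > 50000 nM. The step of an at least 7.1-fold higher number from compound 1 to compound 2 (0.85 log units; beyond the scatter) therefore ends at the limit of > 50000 nM in this assay, at which 1 of the 2 values shown sits, rather than at a number. Compound 3 `NC(=S)Nc1cccc(OCCCCCOc2ccc(-c3ccccc3)cc2)c1` differs from compound 2 by phenyl in place of carboxy on an aromatic carbon. Among the measured compounds shown here, only that one measured step bears on this change; it ran the other way, from chloro to carboxy, and was at least modest. Taking the carboxy away again is expected to lower the number, by an at least 6.2-fold lower number from compound 2 to compound 3 (0.79 log units; beyond the scatter). Compound 3 is estimated at 8000 nM, within a range from 2000 nM to 40000 nM.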

Compound 3, half-maximal cytotoxic concentration: > 50000 nM
Compound 3: a limit, no number (the forecaster's own chance of this, stated with the estimate: 15%); middle value at least 6.2-fold (0.79 log units) away from the limit.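

In this assay, among the compounds shown here, phenyl in place of chloro on this aromatic carbon gives an at least 7.1-fold higher number from compound 1 to compound 3 (0.85 log units; beyond the scatter) and so shows that carboxy is not the only group here that moves the number up from that of compound 1. The value of compound 3 is a limit of the assay, not a number. The step between compound 2 and compound 3 cannot be read, because both stop at the same limit: the limit of > 50000 nM in this assay, at which 2 of the 3 values shown sit.

Going by these compounds, how far compound 2 and compound 3 lie past that limit stays open. So does whether an amine or a methyl on this aromatic carbon would also raise the number.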